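Trading a Ring for a Short Ether Chain

This account rests on a few compounds, and the source may have more. Where it says the series, first, only, none or still open, it means among the compounds named here.

Compound 2 `CC(C(=O)NCc1ccc(C(C)(C)C)nc1OC1CCCCC1)c1ccc(NS(C)(=O)=O)c(F)c1` is one of two related compounds tested in an assay on cells for antagonist activity at transient receptor potential cation channel subfamily V member 1 (Homo sapiens), read by FLIPR and calcium flux, with a stated time of 6 min; a higher number here means a weaker inhibitor, a lower number a stronger inhibitor. In this assay compound 2 gives 2.5 nM, and compound 1 `CCCCCCOc1nc(C(C)(C)C)ccc1CNC(=O)C(C)c1ccc(NS(C)(=O)=O)c(F)c1` gives 2.7 nM; the step of a 1.1-fold lower number from compound 1 to compound 2 (0.03 log units; within the scatter) lies within the scatter, so the two compounds stand level. Compound 3 `COCCCOc1nc(C(C)(C)C)ccc1CNC(=O)C(C)c1ccc(NS(C)(=O)=O)c(F)c1` has not yet been measured. It differs from compound 2 in one place: 3-methoxypropyl in place of cyclohexyl on an oxygen on an aromatic ring. Among the measured compounds shown here, the only measured step touches this same oxygen, and it shows that exchanging hexyl for cyclohexyl there changed nothing beyond the scatter. For the measured compounds named here, the hydrogen-bond acceptor carried by the entering 3-methoxypropyl group has no counterpart among the measured compounds, so that part of the change is untested. Compound 3 is therefore expected to give a somewhat weaker result, a 2.4-fold higher number from compound 2 to compound 3 (0.38 log units; beyond the scatter), with an estimate of 6 nM and a range from 2 nM to 20 nM.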

Compound 3, inhibition constant: 5.6 nM
Compound 3: middle estimate off by 1.1-fold (0.03 log units), on the high side; the measured number falls inside the stated range.
By their numbers in this assay, from the lowest: compounds 2 and 1 (each within the scatter of the next); then compound 3.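

In this assay, the group on this oxygen is no longer shown to be interchangeable: hexyl and cyclohexyl stood level, but the change to 3-methoxypropyl gives a 2.2-fold higher number from compound 2 to compound 3 (0.35 log units; beyond the scatter) and is modest in size. Compared with the open chain of compound 1, placing methoxy where propyl stood, three bonds along the chain from an oxygen on an aromatic ring, gives a 2.1-fold higher number from compound 1 to compound 3 (0.32 log units; beyond the scatter) and shows that a change far out on the chain can also register. Nothing here explains why either step occurs.

The compounds shown leave open whether the chain oxygen itself matters or its place along the chain, which a plain pentyl chain or a 2-methoxyethyl group could help separate. As far as these compounds go, it also remains open how an amine or a carboxylic acid at the end of the chain would fare.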